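The source may report more compounds than this note shows. Statements on the series, on what has been measured and on what is new or still open speak of the compounds shown alone.

Compound 1 `COc1ccc(C(=O)c2ccc(OC)c3c2C=CC(C)(C)O3)c(NC(=O)CO)c1` and compound 2 `COc1ccc(C(=O)c2ccc3c(c2)C=CC(C)(C)O3)c(NC(=O)CO)c1` share most of their structure, but how their two cores differ is not broken down here. In a functional assay on HCT-8 cells (Homo sapiens) for antiproliferative activity, read by MTT assay, with a stated time of 48 h (a lower number here means a stronger inhibitor, a higher number a weaker inhibitor), compound 1 gives 630 nM, while in this assay compound 2 gives 250 nM, the lowest number among the measured compounds. Compound 3 `COc1ccc(C(=O)c2ccc(OC)c3c2C=CC(C)(C)O3)c(NC(=O)CN)c1` is made from compound 1 by one change: amino in place of hydroxy on a saturated chain carbon bound to a carbonyl carbon. In this assay compound 3 gives 1050 nM, so that step is a 1.7-fold higher number from compound 1 to compound 3 (0.22 log units; within the scatter). Compound 4 `COc1ccc(C(=O)c2ccc3c(c2)C=CC(C)(C)O3)c(NC(=O)CN)c1` is made from compound 2 by the same change in the same place: amino in place of hydroxy on a saturated chain carbon bound to a carbonyl carbon. For compound 4 the step is expected to be about a 1.7-fold higher number from compound 2 to compound 4 (0.23 log units; within the scatter), resting on the earlier step of compound 1 given by a 1.7-fold higher number from compound 1 to compound 3 (0.22 log units; within the scatter). Compound 4 is therefore estimated at 420 nM, most likely between 200 nM and 900 nM.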

Compound 4, half-maximal inhibitory concentration: 490 nM
The estimate for compound 4 lay 1.2-fold (0.07 log units) below the measured number; the range from low to high includes it.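

Putting amino in place of hydroxy on the saturated chain carbon bound to a carbonyl carbon gives, in this assay, a 2.0-fold higher number from compound 2 to compound 4 (0.29 log units; within the scatter). Set beside the earlier step, the same change reads alike on the two cores: the same change on two cores in this assay, a 1.7-fold higher number (0.22 log units; within the scatter) from compound 1 to compound 3 and a 2.0-fold higher number (0.29 log units; within the scatter) from compound 2 to compound 4, 1.2-fold (0.07 log units) apart, within the scatter of two such steps. This shows that the step carried over from one core to the other here, but each step is small enough to be scatter, so it does not show that the change itself shifts the number, and two cores say nothing about a third.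

Open, as far as these compounds go, is how other groups in the same place would read, such as a dimethylamine, a carboxylic acid or a longer chain. Also open, from the compounds shown here alone, is whether the agreement would hold on any further core.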